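Swapping the dimethoxyphenyl arm for a thiophene

The compounds below may be only part of what the source reports. "The series", "measured", "known", "first", "only" and "open" are said of these compounds alone.

Measured so far:
- compound 1, `COc1ccc(-c2nn3cc(-c4cccc(N)c4)nc3s2)cc1OC`: 14000 nM
- compound 2, `C=C(Br)C(=O)Nc1cccc(-c2cn3nc(-c4ccc(OC)c(OC)c4)sc3n2)c1`: 380 nM
- compound 3, `COc1ccc(-c2csc3nc(-c4cccc(N)c4)cn23)cc1`: 6100 nM

For the measured compounds named here, in a functional assay on CCRF-CEM cells (Homo sapiens) for inhibition, read by cell counting, with a stated time of 3 days (a lower number here means a stronger inhibitor, a higher number a weaker inhibitor), compound 2 gives the lowest of the three numbers; compound 3 sits a 37-fold lower number from compound 1 to compound 2 (1.57 log units; beyond the scatter) apart from compound 1 is the only single-point step known, and it concerns the amide, not the arm changed here. Compound 4, `C=C(Br)C(=O)Nc1cccc(-c2cn3nc(-c4cccs4)sc3n2)c1`, differs from compound 2 by thiophen-2-yl in place of 3,4-dimethoxyphenyl on an aromatic carbon. Going by the values given here, no measured step bears on this change, so the expectation rests only on compound 2 itself. A modest weakening is expected, a 2.1-fold higher number from compound 2 to compound 4 (0.32 log units; beyond the scatter), because compound 2 gives 380 nM and the new arm is smaller. Compound 4 is therefore estimated at 800 nM, within 200 nM to 3200 nM.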

Compound 4, half-maximal inhibitory concentration: 410 nM
The estimate for compound 4 lay 2.0-fold (0.29 log units) above the measured number; low and high end bracket the measured number.
By their numbers in this assay, from the lowest: compounds 2 and 4 (each within the scatter of the next); then compound 3; then compound 1.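

In this assay the change at this position gives a 1.1-fold higher number from compound 2 to compound 4 (0.03 log units; within the scatter), so thiophen-2-yl, with fewer heavy atoms and no oxygen, serves here as well as 3,4-dimethoxyphenyl. For the compounds shown here, the earlier compounds showed only how much the amide matters, and this is the first reading of the arm on the aromatic carbon next to the ring sulfur. Nothing measured here explains this result. Still open, on these data alone, is how a simple phenyl, a furan-2-yl or a longer alkyl chain would behave on this carbon. Also open, as far as these compounds go, is whether thiophen-2-yl would give a similar number alongside the free amine of compound 1.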